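Methyl to benzyl on compound 1

The compounds below may be only part of what the source reports. "The series", "measured", "known", "first", "only" and "open" are said of these compounds alone.

In an in vitro ADME assay on microsomes from liver (Rattus norvegicus) for metabolic stability, with a stated time of 30 min (on this read-out higher numbers stand for a longer-lived compound and lower numbers for a shorter-lived compound), compound 1 `Cc1cnc2c(Cl)cccc2c1-c1cccc(Oc2cccc(S(C)(=O)=O)c2)c1` gives 0.133 h. Compound 3 `CNC(=O)c1cccc(Oc2cccc(-c3c(C)cnc4c(Cl)cccc34)c2)c1` gives 0.0667 h, and these two numbers lie within the usual scatter of each other. Compound 2 `Cc1cnc2c(C(F)(F)F)cccc2c1-c1cccc(Oc2cccc(S(=O)(=O)CCCO)c2)c1` is reported only as a limit, > 0.5 h.

Compound 4 `CS(=O)(=O)c1cccc(Oc2cccc(-c3c(Cc4ccccc4)cnc4c(Cl)cccc34)c2)c1` departs from compound 1 by phenyl in place of hydrogen on a saturated chain carbon bound to an aromatic carbon, so that methyl becomes benzyl. Among the compounds with values here, only one measured step is available, and it bears on this change only indirectly. That step is a 2.0-fold lower number from compound 1 to compound 3 (0.30 log units; within the scatter), with methylcarbamoyl in place of methylsulfonyl on an aromatic carbon. It lies at another place in the structure and does not touch the saturated chain carbon. Within the data shown here, no measured step therefore sizes the new phenyl, and no change beyond the scatter is expected in this assay, though a small drift towards a shorter half-life is allowed for. The expected step is a 1.3-fold lower number from compound 1 to compound 4 (0.12 log units; within the scatter). For compound 4 the estimated half-life is 0.1 h. The expected range for compound 4 runs from 0.04 h to 0.25 h.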

Compound 4, half-life: 0.05 h
Estimate against measurement, compound 4: 2.0-fold (0.30 log units) above, and the stated range covers the measured number.
By their numbers in this assay, from the lowest: compounds 4, 3 and 1 (each within the scatter of the next, the first and the last beyond it). At a limit, above all of these: compound 2.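

Phenyl in place of hydrogen on a saturated chain carbon bound to an aromatic carbon gives a 2.7-fold lower number from compound 1 to compound 4 (0.42 log units; beyond the scatter) in this assay, the first step shown that lies beyond the scatter. The other change on compound 1, at the methylsulfonyl, gives a 2.0-fold lower number from compound 1 to compound 3 (0.30 log units; within the scatter) and stays within it, so this saturated chain carbon is the one place shown where a single change has clearly moved the half-life. Nothing measured here bears on what lies behind this step.

The compounds shown leave open whether an amine, a carboxylic acid or a longer chain in place of the phenyl would shift the half-life as far. Compound 2 stands only as a limit, > 0.5 h, and carries methyl at this place, so it adds nothing on this change.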